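Fluoro on the pendant phenyl of the pyrrolidinyl analogue

The compounds below may be only part of what the source reports. "The series", "measured", "known", "first", "only" and "open" are said of these compounds alone.

Measured so far:
- compound 1 `COc1cc2c(Oc3ccc(NC(=O)c4cc(-c5ccccc5)ccn4)cc3F)ccnc2cc1OCCCN1CCN(C)CC1`: 91 nM
- compound 2 `COc1cc2c(Oc3ccc(NC(=O)c4cc(-c5ccc(F)cc5)ccn4)cc3F)ccnc2cc1OCCCN1CCCCC1`: 250 nM
- compound 3 `COc1cc2c(Oc3ccc(NC(=O)c4cc(-c5ccccc5)ccn4)cc3F)ccnc2cc1OCCCN1CCCC1`: 130 nM

In a functional assay on NCI-H460 cells (Homo sapiens) for cytotoxicity, read by MTT assay, with a stated time of 72 h (a lower number here means a stronger inhibitor, a higher number a weaker inhibitor), compound 3 gives 130 nM, the second highest of the three numbers; its nearest neighbour is compound 1 and its furthest compound 2, and both gaps sit within the scatter. For the measured compounds named here, the one directly comparable step, a 1.4-fold higher number from compound 1 to compound 3 (0.15 log units; within the scatter), shows that exchanging the basic amine at the end of the three-carbon chain moves the number very little.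

Compound 4 `COc1cc2c(Oc3ccc(NC(=O)c4cc(-c5ccc(F)cc5)ccn4)cc3F)ccnc2cc1OCCCN1CCCC1` takes the next step from compound 3: fluoro in place of hydrogen on an aromatic carbon. Going by the values given here, no measured pair isolates this change. Compound 2 carries the same fluoro but a different amine, and its value against compound 3 shows only a gap within the scatter; compound 1 against compound 2 differs in two places at once and cannot be read as one step. With the amine exchange known to be near-neutral, the fluoro is expected to shift this assay little, if at all, and perhaps slightly toward a higher number; the expected step is a 1.3-fold higher number from compound 3 to compound 4 (0.12 log units; within the scatter). Compound 4 is therefore estimated at 170 nM, within a range of 80 nM to 400 nM.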

Compound 4, half-maximal inhibitory concentration: 370 nM
Estimate against measurement, compound 4: 2.2-fold (0.34 log units) below; the measured number falls inside the stated range.
By their numbers in this assay, from the lowest: compounds 1, 3, 2 and 4 (each within the scatter of the next, the first and the last beyond it).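

In this assay, for the compounds shown here, the change from phenyl to 4-fluorophenyl on the pyrrolidinyl analogue gives the first isolated reading at this position (a 2.8-fold higher number from compound 3 to compound 4 (0.45 log units; beyond the scatter)), a modest step beyond the scatter, so fluoro in place of hydrogen on this aromatic carbon is not neutral here. With the 4-fluorophenyl group held constant, the amine exchange stays within the scatter (a 1.5-fold higher number from compound 2 to compound 4 (0.17 log units; within the scatter)), as it does with the unsubstituted phenyl group (a 1.4-fold higher number from compound 1 to compound 3 (0.15 log units; within the scatter)). Nothing available explains the step with fluoro.

From the compounds shown here alone, whether the step is particular to fluoro remains open, and chloro, methoxy or nitrile on the same aromatic carbon would address this. Also open, going by these compounds, is whether the step with fluoro carries over to the 4-methylpiperazin-1-yl analogue.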